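A longer chain on compound 3

The source may report more compounds than this note shows. Statements on the series, on what has been measured and on what is new or still open speak of the compounds shown alone.

Compound 1 `CN(C)CCCCn1c(N)c(C#N)c2nc(C#N)c(C#N)nc21`: > 50000 nM
Compound 2 `CN(C)CCCCn1c(N)c(-c2nc3ccccc3o2)c2nc(C#N)c(C#N)nc21`: 1950 nM
Compound 3 `CN(C)CCn1c(N)c(-c2nc3ccccc3s2)c2nc(C#N)c(C#N)nc21`: > 50000 nM

All three compounds were tested in a functional assay on HeLa cells (Homo sapiens) for antiproliferative activity, read by MTT assay, with a stated time of 48 h; a higher number here means a weaker inhibitor, a lower number a stronger inhibitor. Compound 1 gives > 50000 nM, which is a limit of the assay and not a number. Compound 3 gives > 50000 nM, which is also a limit and not a number. It therefore sits at the limit of > 50000 nM in this assay, at which 2 of the 3 values shown sit.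

Compound 4 `CN(C)CCCCn1c(N)c(-c2nc3ccccc3s2)c2nc(C#N)c(C#N)nc21` differs from compound 3 by 2-(dimethylamino)ethyl in place of dimethylamino on a saturated chain carbon, two bonds along the chain from an aromatic nitrogen. In words, this is 2-(dimethylamino)ethyl in place of dimethylamino on a saturated chain carbon, two bonds along the chain from an aromatic nitrogen. Compound 4 thus gains the 4-(dimethylamino)butyl chain already found in compound 1 and compound 2.

Going by the values given here, no measured step changes this chain alone. The closest guide is the large step of an at least 25-fold lower number from compound 1 to compound 2 (1.40 log units; beyond the scatter), where 1,3-benzoxazol-2-yl replaces cyano on an aromatic carbon while that chain stays the same. Among the compounds with values here, compound 4 keeps the chain of compound 2 but carries a different ring group, and no measured step covers that swap. Even so, a large move to a lower number is expected, on the strength of compound 2 at 1950 nM. A result still at the limit remains possible. The expected change is an at least 16-fold lower number from compound 3 to compound 4 (1.22 log units; beyond the scatter). For compound 4 the estimated value is 3000 nM, with an expected range of 800 nM to 20000 nM.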

Compound 4, half-maximal inhibitory concentration: 18700 nM
For compound 4 the middle estimate is 6.2-fold (0.79 log units) below the measured one, within the range that was stated.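

Going by these compounds alone, with the 1,3-benzothiazol-2-yl group held fixed, moving from the 2-(dimethylamino)ethyl chain to the 4-(dimethylamino)butyl chain gives an at least 2.6-fold lower number from compound 3 to compound 4 (0.42 log units; beyond the scatter), the first step here that changes the chain alone. With the 4-(dimethylamino)butyl chain held fixed, the ring group matters too: 1,3-benzothiazol-2-yl in place of 1,3-benzoxazol-2-yl gives a 9.6-fold higher number from compound 2 to compound 4 (0.98 log units; beyond the scatter), so these two similar groups are not interchangeable on this aromatic carbon. 1,3-benzothiazol-2-yl in place of cyano still gives an at least 2.6-fold lower number from compound 1 to compound 4 (0.42 log units; beyond the scatter), and this step and the chain step are only lower bounds on the true size, since each starts from a value that is a limit of the assay: the limit of > 50000 nM in this assay, at which 2 of the 4 values shown sit.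

The compounds shown leave open whether the 1,3-benzoxazol-2-yl group responds to chain length in the same way, and whether a 3-(dimethylamino)propyl chain or a chain longer than 4-(dimethylamino)butyl would move the number further. They also leave open what happens when the dimethylamino end of the chain is replaced by a ring amine such as piperidine or morpholine.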